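The source may report more compounds than this note shows. Statements on the series, on what has been measured and on what is new or still open speak of the compounds shown alone.

Measured compounds:
compound 1 `COc1ccc(-c2[nH]c3ccccc3c2/C=C(\C#N)S(=O)(=O)c2ccccc2)cc1` — 383 nM
compound 2 `COc1ccc2[nH]c(-c3ccccc3)c(C=C(C#N)C#N)c2c1` — 2300 nM
compound 3 `O=C(/C(=C\c1c(-c2ccccc2)[nH]c2ccccc12)S(=O)(=O)c1ccccc1)c1ccccc1` — 15600 nM

These three share an indole core bearing a pendant phenyl ring and a two-carbon chain that carries the varying groups. In a functional assay on M14 cells (Homo sapiens) for inhibition, read by sulforhodamine B assay, with a stated time of 48 h (on this read-out lower numbers stand for stronger inhibition of growth and higher numbers for weaker inhibition of growth), compound 3 gives 15600 nM, the highest of the three numbers; its gap to compound 2 and its larger gap to compound 1 both lie beyond the scatter, so compound 3 is the weakest inhibitor of growth among the measured set.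

Compound 4 `N#C/C(=C\c1c(-c2ccccc2)[nH]c2ccccc12)S(=O)(=O)c1ccccc1` has not yet been measured. It differs from compound 3 in one place: cyano in place of benzoyl on a double-bonded chain carbon bound to a double-bonded chain carbon and a sulfonyl sulfur. In this assay the step from compound 3 to compound 4 is expected to run downward, toward stronger inhibition, and well beyond the scatter, because compound 1 carries this same cyano and sulfonyl pairing and gives 383 nM. Compound 4 is therefore estimated at 700 nM, with a range from 200 nM to 3000 nM, meaning an expected step of a 22-fold lower number from compound 3 to compound 4 (1.35 log units; beyond the scatter).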

Compound 4, concentration for 50% growth inhibition: 3800 nM
Compound 4: middle estimate off by 5.4-fold (0.73 log units), on the low side; the measured number lies above the stated range.
By their numbers in this assay, from the lowest: compound 1; then compounds 2 and 4 (each within the scatter of the next); then compound 3.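

In this assay, the step at this chain carbon is a 4.1-fold lower number from compound 3 to compound 4 (0.61 log units; beyond the scatter), so a cyano group gives stronger inhibition of growth than the much larger benzoyl. With hydrogen in place of methoxy on an aromatic carbon, the step is a 9.9-fold higher number from compound 1 to compound 4 (1.00 log units; beyond the scatter), which shows that the cyano and sulfonyl pairing alone does not reach the level of compound 1. Nothing on hand gives a reason for either step.

On these data alone, whether benzoyl costs as much when the methoxy is present stays open. So does how an amide or a carboxylic acid would fare at this chain carbon.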